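The source may report more compounds than this note shows. Statements on the series, on what has been measured and on what is new or still open speak of the compounds shown alone.

Measured so far:
- Compound 1 `COc1cccc(C(=O)n2c(-c3cn(C)c4ccccc34)nc3ccccc32)c1`: 15700 nM
- Compound 2 `COc1ccc(C(=O)n2c(-c3cn(C)c4ccccc34)nc3ccccc32)cc1`: 16300 nM
- Compound 3 `Cn1cc(-c2nc3ccccc3n2C(=O)c2ccccc2Br)c2ccccc21`: 70100 nM

These values come from a functional assay on MCF7 cells (Homo sapiens) for inhibition, read by MTT assay, with a stated time of 24 h; a lower number here means a stronger inhibitor of growth, a higher number a weaker inhibitor of growth. Compound 3, at 70100 nM, has the highest number of the three and is thus the weakest inhibitor so far. Compound 4 `Cn1cc(-c2nc3ccccc3n2C(=O)c2cccc(Br)c2)c2ccccc21` has 3-bromophenyl in place of 2-bromophenyl on a carbonyl carbon.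

Within the data shown here, no measured step makes this exact change, so the evidence is indirect. Exchanging 3-methoxyphenyl for 4-methoxyphenyl gives a 1.0-fold higher number from compound 1 to compound 2 (0.02 log units; within the scatter). Bringing in 2-bromophenyl gives two modest steps, a 4.5-fold higher number from compound 1 to compound 3 (0.65 log units; beyond the scatter) and a 4.3-fold higher number from compound 2 to compound 3 (0.63 log units; beyond the scatter). Among the measured compounds shown here, compound 3 is also the only measured compound with a bromophenyl group, so the data cannot separate the effect of the bromine from that of its place on the ring.

A modest drop towards compound 1 and compound 2 in this assay is therefore the cautious expectation, with no change also possible. The expected step is a 2.3-fold lower number from compound 3 to compound 4 (0.37 log units; beyond the scatter). Compound 4 is estimated at 30000 nM, with an expected range of 12000 nM to 75000 nM.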

Compound 4, concentration for 50% growth inhibition: 63400 nM
Compound 4: the middle estimate sits 2.1-fold (0.32 log units) below what was measured; the range from low to high includes it.
By their numbers in this assay, from the lowest: compounds 1 and 2 (each within the scatter of the next); then compounds 4 and 3 (each within the scatter of the next).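

In this assay, a 1.1-fold lower number from compound 3 to compound 4 (0.04 log units; within the scatter) shows that the two bromophenyl compounds cannot be told apart, so shifting the bromine from the 2-bromophenyl to the 3-bromophenyl arrangement makes no readable difference. Among these compounds, the gap to the methoxy compounds remains, with a 3.9-fold higher number from compound 2 to compound 4 (0.59 log units; beyond the scatter) and a 4.0-fold higher number from compound 1 to compound 4 (0.61 log units; beyond the scatter), and the second of these is the first single exchange of bromo for methoxy on an aromatic carbon, which the earlier compounds did not offer. No measurement here gives a reason for this gap.

Going by these compounds, it remains open whether the higher numbers belong to bromine in particular or would also appear with chloro on the same ring. Plain phenyl, an amine or a carboxylic acid on this ring could show whether either substituent matters at all.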